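The step from compound 1 to compound 3

A few compounds are considered here, and "the series" means these few. Any claim that something is new, unique, unknown or untested is made for them only; others in the source may bear on it.

Compound 1 (`Cn1cc(SCC(=O)NCc2ccc(Cl)c(Cl)c2)c2ccccc21`) : > 100000 nM (a limit)
Compound 2 (`COc1ccccc1CNC(=O)CSc1c[nH]c2cc(Br)ccc12`) : > 100000 nM (a limit)

In an ADME assay on HEK-293T cells (Homo sapiens) for cytotoxicity, read by CCK-8 assay, with a stated time of 24 h (on this read-out lower numbers stand for higher toxicity in this test and higher numbers for lower toxicity in this test), compound 1 stands at > 100000 nM, which is a limit of the assay and not a number. Compound 2 gives > 100000 nM, which is likewise a limit. Together they show (the limit of > 100000 nM in this assay, at which 2 of the 2 values shown sit), and no numerical value is available for either compound.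

Compound 3 (`Cn1cc(SCC(=O)NCc2ccccc2)c2ccccc21`) has not yet been measured. It keeps the core of compound 1, and the difference between the two is counted as follows: phenyl in place of 3,4-dichlorophenyl on a saturated chain carbon bound to an amide-type nitrogen. In words, it has phenyl in place of 3,4-dichlorophenyl on a saturated chain carbon bound to an amide-type nitrogen.

Among the compounds with values here, no step between measured compounds is available as a guide. In this assay the expected change, a number no higher from compound 1 to compound 3 (the limit leaves the size open), is none beyond the usual scatter and has no expected direction. This expectation rests only on (the limit of > 100000 nM in this assay, at which 2 of the 2 values shown sit). Compound 3 is estimated at 100000 nM (expected range 50000 nM to 200000 nM).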

Compound 3, half-maximal cytotoxic concentration: 95500 nM
Beside the measured number, compound 3's estimate is 1.0-fold (0.02 log units) above it; measured number inside the range.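

In this assay, within the data shown here, compound 3 gives 95500 nM, the only value shown so far that is a number and not a limit. Compound 1 stands at > 100000 nM, which is a limit of the assay and not a number. With phenyl in place of 3,4-dichlorophenyl on a saturated chain carbon bound to an amide-type nitrogen, the step reads an at least 1.0-fold lower number from compound 1 to compound 3 (0.01 log units; that floor lies within the scatter), so the two chlorine atoms are not shown to make a difference in this assay that can be told from the scatter, although a larger difference is not ruled out.

As far as these compounds go, the true size of this step stays open, since the values shown crowd at the upper end of what this assay can report: the limit of > 100000 nM in this assay, at which 2 of the 3 values shown sit. Also open is how the read-out would respond to an amine or a carboxylic acid on the phenyl ring, or to a longer chain in place of the saturated chain carbon bound to the amide-type nitrogen, and whether any such change would give a number clearly apart from that of compound 3.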